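Bromo in Place of Methyl: What to Expect for Compound 3

The source may hold more compounds than are shown below. What is called first, only, known or untested is meant among the compounds shown, and "the series" means these compounds.

Measured so far:
compound 1 `CCOc1ccc(C(=O)/C=C/c2ccc(C)cc2)cc1` gives 210 nM in an assay on isolated protein for inhibition of Amine oxidase [flavin-containing] B (Homo sapiens); a higher number here means a weaker inhibitor, a lower number a stronger inhibitor
compound 2 `O=C(/C=C/c1cccc(F)c1)c1ccc(-n2ccnc2)cc1` gives > 10000 nM in this assay

Compound 1 holds the only measured number shown; the one other value is a limit. For compound 2, the value in this assay is a limit of the assay and not a number (the limit of > 10000 nM in this assay, at which 1 of the 2 values shown sits).

Compound 3 `CCOc1ccc(C(=O)/C=C/c2ccc(Br)cc2)cc1` differs from compound 1 by bromo in place of methyl on an aromatic carbon. Among the compounds with values here, no step between measured compounds offers a guide for this change. The step of a 1.1-fold lower number from compound 1 to compound 3 (0.02 log units; within the scatter) is expected to be small, within the usual scatter, in no clear direction. Compound 3 is therefore estimated at 200 nM, with a range from 70 nM to 600 nM.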

Compound 3, half-maximal inhibitory concentration: 210 nM
Beside the measured number, compound 3's estimate is 1.1-fold (0.02 log units) below it; low and high end bracket the measured number.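

In this assay, within the data shown here, bromo in place of methyl on an aromatic carbon para to a large group gives no change at the digits printed from compound 1 to compound 3 (within the scatter) and is the first readable step at this position. The assay therefore does not tell these two groups apart here, at least on the shared core of compound 1 and compound 3. Nothing measured among these compounds accounts for this match. On these data alone, whether an amine or a carboxylic acid at this position would leave the number equally unmoved stays open. A single pair of groups cannot show how far this tolerance extends.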